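This account rests on a few compounds, and the source may have more. Where it says the series, first, only, none or still open, it means among the compounds named here.

Compound 1 `N#CCC(=O)N/N=C1\C(=O)Nc2ccc(S(=O)(=O)N3CCOCC3)cc21` gives 27700 nM in a functional assay on MCF7 cells (Homo sapiens) for cytotoxicity, read by sulforhodamine B assay, with a stated time of 24 h; a lower number here means a stronger inhibitor, a higher number a weaker inhibitor. Compound 2 `O=C1Nc2ccc(S(=O)(=O)N3CCOCC3)cc2/C1=N/c1ccc(Br)cc1` gives 44800 nM. Compound 3 `O=C1Nc2ccc(S(=O)(=O)N3CCOCC3)cc2/C1=N/c1ccc(C(=O)O)cc1` gives 26700 nM.

Compound 2 has the highest of the three numbers in this assay, but the steps of a 1.6-fold higher number from compound 1 to compound 2 (0.21 log units; within the scatter) and a 1.7-fold lower number from compound 2 to compound 3 (0.22 log units; within the scatter) both fall within the scatter, so it cannot be set apart from the other two.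

Compound 4 `O=C1Nc2ccc(S(=O)(=O)N3CCOCC3)cc2/C1=N/c1ccc(Cl)cc1` differs from compound 2 by chloro in place of bromo on an aromatic carbon. Among the compounds with values here, the only measured step at the same position is a 1.7-fold lower number from compound 2 to compound 3 (0.22 log units; within the scatter), which stayed within the scatter; no other step bears on this change. The expectation for compound 4 in this assay is therefore no step beyond the scatter, a 1.1-fold lower number from compound 2 to compound 4 (0.05 log units; within the scatter). Compound 4 is estimated at 40000 nM, with a range from 18000 nM to 90000 nM.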

Compound 4, half-maximal inhibitory concentration: 44300 nM
Compound 4: middle estimate off by 1.1-fold (0.04 log units), on the low side; the measured number falls inside the stated range.
By their numbers in this assay, from the lowest: compounds 3, 1, 4 and 2 (each within the scatter of the next).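

In this assay, chloro in place of bromo at this position, para to a large group, gives a 1.0-fold lower number from compound 2 to compound 4 (0.00 log units; within the scatter) and so adds a swap of one halogen for another to the steps that stayed within the scatter. Chloro in place of carboxy gives a 1.7-fold higher number from compound 3 to compound 4 (0.22 log units; within the scatter) and 4-chlorophenyl in place of ((cyanomethyl)carbonyl)amino gives a 1.6-fold higher number from compound 1 to compound 4 (0.20 log units; within the scatter), so the four compounds still cannot be set apart. No measurement at hand accounts for this result. The compounds shown leave open whether an amine or a methoxy group at this position would move the number beyond the scatter.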